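Adding a Methoxy Group to a Weakly Active Purine Scaffold

A few compounds are considered here, and "the series" means these few. Any claim that something is new, unique, unknown or untested is made for them only; others in the source may bear on it.

Compound 1, with the structure `COc1ccc(N(C)c2nc(Cl)nc3c2ncn3Cc2cc(OC)cc(OC)c2)cc1`, and compound 2, with the structure `COc1ccc(N(C)c2nc(Cl)nc3c2ncn3Cc2cc(OC)c(OC)c(OC)c2)cc1`, share a core and differ in one place, namely by the change (methoxy in place of hydrogen on an aromatic carbon). In a functional assay on AGS cells (Homo sapiens) for antiproliferative activity, read by MTT assay, with a stated time of 48 h (on this read-out lower numbers stand for stronger inhibition of growth and higher numbers for weaker inhibition of growth), compound 1 gives 69000 nM. In this assay compound 2 gives 85000 nM. The step between them is a 1.2-fold higher number from compound 1 to compound 2 (0.09 log units; within the scatter), so the added methoxy group left the growth inhibition essentially unchanged.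

Compound 3 has the structure `COc1cc(Cn2cnc3c(Cl)ncnc32)cc(OC)c1`; how its core differs from that of compound 1 is not broken down here. In this assay compound 3 reaches only the limit of the measurement and gives > 100000 nM, which is a limit and not a number, as noted in the limit of > 100000 nM in this assay, at which 1 of the 3 values shown sits.

Compound 4, with the structure `COc1cc(Cn2cnc3c(Cl)ncnc32)cc(OC)c1OC`, is not yet measured. Among the measured compounds shown here, it differs from compound 3 by the change (methoxy in place of hydrogen on an aromatic carbon), which is the same change as the one from compound 1 to compound 2, made at the same kind of place on the ring. Because that earlier step was a 1.2-fold higher number from compound 1 to compound 2 (0.09 log units; within the scatter), the step from compound 3 to compound 4 is expected to be small as well, roughly a step that the limit leaves unreadable from compound 3 to compound 4. Since compound 3 already sits at the limit of this assay, compound 4 is expected to give about 150000 nM, most likely again only a limit, with a plausible range from 60000 nM to 400000 nM.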

Compound 4, concentration for 50% growth inhibition: > 50000 nM
Compound 4 gave a limit, no number (the forecaster's own chance of this, stated with the estimate: 80%); the middle value lies beyond the limit too.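

In this assay compound 4 gives > 50000 nM as a limit and not a number. No size can be read for the step between compound 3 and compound 4, because both compounds end at a limit of the measurement: the limit of > 50000 nM in this assay, at which 1 of the 4 values shown sits.

The compounds shown leave open how strongly compound 3 and compound 4 inhibit growth, and so whether the added methoxy group changes anything on their shared core.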